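The compounds below may be only part of what the source reports. "The series", "measured", "known", "first", "only" and "open" are said of these compounds alone.

Series notes. The shared core carries a primary amide on a pyrrolidine attached to an aromatic ring that bears a benzyloxy group. Compound 1 `N#Cc1ccccc1COc1ccc([C@H]2CC[C@@H](C(N)=O)N2)cc1` is one member. In an assay on HEK293 cells for inhibition of sodium channel protein type 3 subunit alpha (Homo sapiens), read by electrophysiology, with a stated time of 3.5 min (a higher number here means a weaker inhibitor, a lower number a stronger inhibitor), compound 1 gives > 63000 nM, which is a limit of the assay and not a number. Compound 3 `N#Cc1ccc(COc2ccc([C@H]3CC[C@@H](C(N)=O)N3)cc2)cc1` carries 4-cyanophenyl in place of 2-cyanophenyl on a saturated chain carbon bound to an oxygen on an aromatic ring. In this assay compound 3 gives > 63000 nM, again a limit. The step that the two limits leave unreadable from compound 1 to compound 3 therefore cannot be read. Compound 2 `N#Cc1cc([C@H]2CC[C@@H](C(N)=O)N2)ccc1OCc1ccccc1F` gives > 50100 nM in this assay, a limit as well. Compound 2 thus sits at the limit of > 50100 nM in this assay, at which 1 of the 3 values shown sits, while the limit of > 63000 nM in this assay, at which 2 of the 3 values shown sit, holds the other two. Compound 4 `COc1cc([C@H]2CC[C@@H](C(N)=O)N2)ccc1OCc1ccccc1F` differs from compound 2 by methoxy in place of cyano on an aromatic carbon. Going by the values given here, no measured step bears on this change, and no value in the set is a number. Compound 4 is expected to remain at the limit, estimated at 60000 nM (range 10000 nM to 300000 nM), a step that the limit leaves unreadable from compound 2 to compound 4 that is expected to mean no change beyond the scatter.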

Compound 4, half-maximal inhibitory concentration: 63100 nM
Compound 4: middle estimate off by 1.1-fold (0.02 log units), on the low side; measured number inside the range.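

The step between compound 2 and compound 4 cannot be read: the value for compound 2 is a limit of the assay and not a number. The compounds shown leave open whether methoxy in place of cyano changes inhibition at all.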